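Moving a methoxy group around the outer ring

The source may report more compounds than this note shows. Statements on the series, on what has been measured and on what is new or still open speak of the compounds shown alone.

Measured so far:
Compound 1 `CCOc1ccc(C)c(-c2cccc(COc3ccc(OCC(=O)O)c(F)c3)c2)c1`: 220 nM
Compound 2 `COc1cccc(-c2cccc(COc3ccc(OCC(=O)O)c(F)c3)c2)c1`: 540 nM
Compound 3 `CCOc1cccc(-c2cccc(COc3ccc(OCC(=O)O)c(F)c3)c2)c1`: 480 nM

All three share the same core and were tested in a functional assay on CHO cells for agonist activity at Free fatty acid receptor 1 (Homo sapiens), read by FLIPR and calcium flux; on this read-out lower numbers stand for an effect already at smaller amounts and higher numbers for an effect only at larger amounts of compound. Compound 3 stands second highest of the three numbers; its step from compound 2 is a 1.1-fold lower number from compound 2 to compound 3 (0.05 log units; within the scatter), while compound 1 is set apart by a 2.2-fold higher number from compound 1 to compound 3 (0.34 log units; beyond the scatter). Compound 4 `COc1ccc(-c2cccc(COc3ccc(OCC(=O)O)c(F)c3)c2)cc1` differs from compound 3 in that (4-methoxyphenyl in place of 3-ethoxyphenyl on an aromatic carbon). For the measured compounds named here, no measured pair shows a methoxy group moved to this position; the only step touching the same ring at the same place is a 1.1-fold lower number from compound 2 to compound 3 (0.05 log units; within the scatter), which is small. The step of a 1.0-fold higher number from compound 3 to compound 4 (0.02 log units; within the scatter) is therefore expected to stay within the scatter. Compound 4 is estimated to give 500 nM, within a range from 200 nM to 1300 nM.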

Compound 4, half-maximal effective concentration: 170 nM
Estimate against measurement, compound 4: 2.9-fold (0.47 log units) above; the whole stated range lies above it.
By their numbers in this assay, from the lowest: compounds 4 and 1 (each within the scatter of the next); then compounds 3 and 2 (each within the scatter of the next).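

Where the methoxy group sits on the outer ring matters: in this assay, going from 3-methoxyphenyl to 4-methoxyphenyl gives a 3.2-fold lower number from compound 2 to compound 4 (0.50 log units; beyond the scatter), a shift beyond the scatter. The change from 3-ethoxyphenyl gives a 2.8-fold lower number from compound 3 to compound 4 (0.45 log units; beyond the scatter) and points the same way, whereas a 1.3-fold lower number from compound 1 to compound 4 (0.11 log units; within the scatter) stays within the scatter, so this simple 4-methoxyphenyl group performs on a par with the 5-ethoxy-2-methylphenyl group. Nothing available explains this shift. Still open, on these data alone, is whether a longer chain, such as propoxy, or an amine at that same place would keep the lower number.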